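A Fluorine Added to the Benzyloxy Tail

A few compounds are considered here, and "the series" means these few. Any claim that something is new, unique, unknown or untested is made for them only; others in the source may bear on it.

Three compounds share one core and differ only in the group on an aromatic carbon. Compound 1 `CC(C(=O)NCc1ccc(C(F)(F)F)cc1N1CCCC1)c1ccc(NS(C)(=O)=O)c(F)c1` carries a pyrrolidin-1-yl there; in an assay on CHO cells for antagonist activity at transient receptor potential cation channel subfamily V member 1 (Homo sapiens), read by FLIPR (a lower number here means a stronger inhibitor, a higher number a weaker inhibitor), compound 1 gives 2.3 nM. Compound 2 `CC(C(=O)NCc1ccc(C(F)(F)F)cc1N1CCC(C)(C)CC1)c1ccc(NS(C)(=O)=O)c(F)c1` carries a 4,4-dimethylpiperidin-1-yl instead, and in this assay compound 2 gives 1.3 nM; the step of a 1.8-fold lower number from compound 1 to compound 2 (0.25 log units; within the scatter) stays within the scatter. Compound 3 `CC(C(=O)NCc1ccc(C(F)(F)F)cc1OCc1ccccc1)c1ccc(NS(C)(=O)=O)c(F)c1` carries a benzyloxy, and in this assay compound 3 gives 0.9 nM. The step of a 2.6-fold lower number from compound 1 to compound 3 (0.41 log units; beyond the scatter) is modest but beyond the scatter, while a 1.4-fold lower number from compound 2 to compound 3 (0.16 log units; within the scatter) is within it. Compound 3 thus has the lowest number of the three, separated from compound 2 only by a gap within the scatter.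

Compound 4 `CC(C(=O)NCc1ccc(C(F)(F)F)cc1OCc1ccc(F)cc1)c1ccc(NS(C)(=O)=O)c(F)c1` is compound 3 with one change: fluoro in place of hydrogen on an aromatic carbon. Going by the values given here, none of the measured steps touches this part of the molecule; all three vary the group on the core, and the benzyloxy itself has been measured only once. Among the compounds with values here, no measured step therefore bears directly on this change, and the expectation is a step of no more than the scatter in this assay, in either direction. Compound 4 is estimated at 0.8 nM, in a range from 0.3 nM to 2.5 nM, which means an expected step of a 1.1-fold lower number from compound 3 to compound 4 (0.05 log units; within the scatter).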

Compound 4, inhibition constant: 0.5 nM
For compound 4 the middle estimate is 1.6-fold (0.20 log units) above the measured one; the measured number falls inside the stated range.
By their numbers in this assay, from the lowest: compounds 4, 3, 2 and 1 (each within the scatter of the next, the first and the last beyond it).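

Placing a fluoro on the benzyloxy tail gives a step that stays within the scatter in this assay (a 1.8-fold lower number from compound 3 to compound 4 (0.26 log units; within the scatter)), so for this one pair the assay cannot tell the hydrogen and the fluoro on that aromatic carbon apart. This is the first compound shown in which the benzyl part itself is altered, and it shows that one added fluorine atom there still leaves a nanomolar-range inhibitor. Compared with the other groups on the shared core, compound 4 stands clear of the scatter on both sides (a 2.6-fold lower number from compound 2 to compound 4 (0.41 log units; beyond the scatter)) and (a 4.6-fold lower number from compound 1 to compound 4 (0.66 log units; beyond the scatter)), both steps modest, whereas compound 3 stood clear of compound 1 only.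

The compounds shown leave open whether a chloro, a methoxy or a nitrile on the same aromatic carbon would behave as the fluoro does, and whether an amine or a carboxylic acid there would be tolerated at all. No measurement at hand says why any of these steps has the size it has.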